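From furan-3-yl to cyclohexyl: compound 3 to compound 4

The source may report more compounds than this note shows. Statements on the series, on what has been measured and on what is new or still open speak of the compounds shown alone.

In an ADME assay on MDBK cells (Bos taurus) for cytotoxicity, read by MTT assay, with a stated time of 96 h (on this read-out higher numbers stand for lower toxicity in this test and lower numbers for higher toxicity in this test), compound 3 `C/C(=N\NC(N)=S)c1ccc2[nH]c(-c3ccoc3)nc2c1` gives > 100000 nM, which is a limit and not a number. Compound 2 `C/C(=N\NC(N)=O)c1ccc2[nH]c(C3CCCCC3)nc2c1`, which also carries cyclohexyl, gives > 100000 nM, likewise a limit. Compound 3 therefore stands at the limit of > 100000 nM in this assay, at which 2 of the 3 values shown sit. Only compound 1 `COc1ccc(-c2nc3cc(/C(C)=N/NC(N)=S)ccc3[nH]2)cc1` gives a number, 13000 nM.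

Compound 4 `C/C(=N\NC(N)=S)c1ccc2[nH]c(C3CCCCC3)nc2c1` has cyclohexyl in place of furan-3-yl on an aromatic carbon, and the counted difference is cyclohexyl in place of furan-3-yl on an aromatic carbon. Among the compounds with values here, the one measured step at this place is an at least 7.6-fold higher number from compound 1 to compound 3 (0.88 log units; beyond the scatter), with furan-3-yl in place of 4-methoxyphenyl. It shows that the group on this carbon can shift the read-out beyond the scatter, although it involves a different pair of groups. The limit of compound 2 at > 100000 nM argues against expecting a large shift. The estimated change is an at least 2.5-fold lower number from compound 3 to compound 4 (0.39 log units; beyond the scatter), a modest move towards a lower number, and compound 4 may also remain at the limit. For compound 4 the expected value is 40000 nM, with an estimated range of 10000 nM to 100000 nM.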

Compound 4, half-maximal cytotoxic concentration: > 100000 nM
Compound 4: a limit, no number (the forecaster's own chance of this, stated with the estimate: 35%); middle value at least 2.5-fold (0.39 log units) from the limit.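

In this assay, cyclohexyl in place of 4-methoxyphenyl on this aromatic carbon gives an at least 7.6-fold higher number from compound 1 to compound 4 (0.88 log units; beyond the scatter). The move away from the 4-methoxyphenyl compound is therefore not confined to furan-3-yl, since a non-aromatic ring of carbon only goes the same way as a five-membered aromatic ring. The steps from compound 3 and from compound 2 to compound 4 cannot be read, as both ends of each are limits, and the series now gathers at one value: the limit of > 100000 nM in this assay, at which 3 of the 4 values shown sit.

On these data alone, whether the lower number of compound 1 belongs to its methoxy group or to the phenyl ring itself stays open. Also open, as far as these compounds go, is how a plain phenyl ring, or one carrying an amine or a carboxylic acid, would read at this position.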